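This account rests on a few compounds, and the source may have more. Where it says the series, first, only, none or still open, it means among the compounds named here.

Measured in a functional assay on HEp-2 cells (Homo sapiens) for cytotoxicity, read by MTT assay, with a stated time of 72 h, tested at 1.25 ug/mL; a higher number here means more inhibition of growth at the concentration tested, a lower number less inhibition of growth:
- compound 1 `O=C1NC(=S)/C(=C/c2ccc(Cl)cc2)S1`: 0.92%
- compound 2 `O=C1NC(=S)/C(=C/c2cc(Cl)cc(Cl)c2Cl)S1`: 12.6%
- compound 3 `O=C1NC(=S)/C(=C/c2ccccc2Br)S1`: 3.14%

All three compounds share a core and differ in the halogens on the aromatic ring, and all three numbers are small. Compound 1, at 0.92%, lies within the scatter of compound 3. Compound 2, at 12.6%, lies beyond the scatter from compound 1, on the higher side.

The next compound to be tested is compound 4 `O=C1NC(=S)/C(=C/c2ccc(Br)cc2)S1`. It is compound 1 with bromo in place of chloro on an aromatic carbon. For the measured compounds named here, no two measured compounds differ in one place only, so the size of this step cannot be read directly from the data. Going by the values given here, the only guide is compound 3, which also carries bromo and gives 3.14%, close to compound 1. No step beyond the scatter is therefore expected in this assay.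

The expected change is a number 2.1 percentage points higher from compound 1 to compound 4 (within the scatter). For compound 4 the estimated value is 3%, with an expected range from 0% to 12%.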

Compound 4, percent growth inhibition at one concentration: -3.16%
For compound 4 the middle estimate is 6.2 percentage points above the measured one, outside the stated range (below it).
By their numbers in this assay, from the lowest: compounds 4, 1, 3 and 2 (each within the scatter of the next, the first and the last beyond it).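

In this assay, for the compounds shown here, the exchange of bromo for chloro on an aromatic carbon, para to a group of 8 heavy atoms, now gives the first step that can be read between two compounds differing in one place: a number 4.1 percentage points lower from compound 1 to compound 4 (within the scatter). At this position, then, replacing one halogen with the other leaves the number within the scatter, and compound 4 gives -3.16% without separating from compound 1. Nothing measured here offers an explanation for this result.

The steps linking compound 2 and compound 3 to the others cannot be read, so the contribution of the position and number of halogens on the ring remains unresolved. Also open, on these data alone, is whether an amine, a carboxylic acid or a longer chain at this position would give a step beyond the scatter.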